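Trifluoromethyl for chloro on the anilide ring of compound 1

The source may hold more compounds than are shown below. What is called first, only, known or untested is meant among the compounds shown, and "the series" means these compounds.

The study concerns compound 1 `O=C(CN1CCN(C(=O)CCCCN2CCN(c3ccccc3)CC2)CC1)Nc1cccc(Cl)c1`, measured in an assay on cells (Oocyte) for inhibition of Voltage-dependent T-type calcium channel subunit alpha-1H (Homo sapiens), tested at 100 uM (a lower number here means less inhibition, a higher number more inhibition at the concentration tested (going by the name of the read-out)), where compound 1 gives 75.4%. Among the compounds with values here, this is the only number recorded in the set. Compound 2 `CN1CCN(CCCCC(=O)N2CCN(CC(=O)Nc3cccc(Cl)c3)CC2)CC1` was also tested, and in this assay compound 2 reaches only the limit of the assay, < 1%, so it carries no number (the limit of < 1% in this assay, at which 1 of the 2 values shown sits). Within the data shown here, the one step that is fully described, a number at least 74.4 percentage points lower from compound 1 to compound 2 (beyond the scatter), involves methyl in place of phenyl on an amine nitrogen in a ring, a site far from the change considered here.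

Compound 3 `O=C(CN1CCN(C(=O)CCCCN2CCN(c3ccccc3)CC2)CC1)Nc1cccc(C(F)(F)F)c1` is not yet measured. It differs from compound 1 in one place: trifluoromethyl in place of chloro on an aromatic carbon. Among the measured compounds shown here, no measured step touches this end of the molecule, so nothing among the recorded compounds argues for a large step in this assay in either direction. For that reason the step is expected to stay within the usual scatter, with a move of a number 3.4 percentage points lower from compound 1 to compound 3 (within the scatter), and compound 3 is estimated to give 72%, between 45% and 92%.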

Compound 3, a percentage reported as inhibition, at one concentration (the size of the read-out at that concentration, not a potency): 53%
Beside the measured number, compound 3's estimate is 19 percentage points above it, and the stated range covers the measured number.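

In this assay, trifluoromethyl in place of chloro on this aromatic carbon gives a number 22.4 percentage points lower from compound 1 to compound 3 (beyond the scatter), so the anilide end of the molecule also has a bearing on the read-out. The earlier compounds shown here spoke only for the other end of the molecule, where methyl in place of phenyl on an amine nitrogen in a ring gives a number at least 74.4 percentage points lower from compound 1 to compound 2 (beyond the scatter); the new step is modest by comparison, and the exchange at the anilide ring does not remove inhibition at the concentration tested. Nothing given here accounts for the size or the direction of this step, and the one recorded note, on the limit of the assay, does not bear on it.

The compounds shown hold only chloro and trifluoromethyl at this carbon, so it remains open how a fluoro, a methoxy, a nitrile or a plain hydrogen there would compare, and one pair cannot show a trend among such groups. Also open, going by these compounds, is how the same exchange would read on the core of compound 2, which carries methyl on the ring nitrogen.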